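The source may hold more compounds than are shown below. What is called first, only, known or untested is meant among the compounds shown, and "the series" means these compounds.

In an ADME assay on Vero cells (Chlorocebus sabaeus) for cytotoxicity, with a stated time of 24 h (a lower number here means that less compound is tolerated, a higher number that more compound is tolerated), compound 1 (`CCC(CC)O[C@@H]1C=C(C(=O)O)C[C@H](NC(=O)OC(C)(C)C)[C@H]1NC(C)=O`) gives a half-maximal cytotoxic concentration of 750000 nM and sits level with compound 2 (`CCC(CC)O[C@@H]1C=C(C(=O)Nc2ccccc2OC)C[C@H](NC(=O)OC(C)(C)C)[C@H]1NC(C)=O`) at 755000 nM on the same read-out. Compound 3 (`CCC(CC)O[C@@H]1C=C(C(=O)Nc2ccccc2)C[C@H](NC(=O)OC(C)(C)C)[C@H]1NC(C)=O`) has anilino in place of hydroxy on a carbonyl carbon. Going by the values given here, the closest measured change, (2-methoxyphenyl)amino in place of hydroxy, gave a 1.0-fold higher number from compound 1 to compound 2 (0.00 log units; within the scatter) and is the only step that bears on it. No step beyond the scatter is therefore expected in this assay. The expected change is no change at the digits printed from compound 1 to compound 3 (within the scatter) and no more. Compound 3 is estimated at 750000 nM and expected to fall from 400000 nM to 1400000 nM in this read-out.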

Compound 3, half-maximal cytotoxic concentration: 755000 nM
Compound 3: middle estimate off by 1.0-fold (0.00 log units), on the low side, within the range that was stated.
By their numbers in this assay, from the lowest: compounds 1, 2 and 3 (each within the scatter of the next).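

In this assay, anilino in place of hydroxy on the carbonyl carbon gives a 1.0-fold higher number from compound 1 to compound 3 (0.00 log units; within the scatter) and so, like the (2-methoxyphenyl)amino group, leaves the number level. Hydrogen in place of methoxy on the aromatic carbon gives no change at the digits printed from compound 2 to compound 3 (within the scatter) and shows that this read-out does not separate the anilino compound from its methoxy-bearing partner. No available evidence explains why these numbers stay level.
Going by these compounds, whether benzylamino or morpholino on the same carbonyl carbon would also leave the number level remains open, and so does the effect of a chlorine or an amine on the aromatic ring.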